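Ketone to oxime-type group: one change, one expectation

This account rests on a few compounds, and the source may have more. Where it says the series, first, only, none or still open, it means among the compounds named here.

Among the compounds with values here, compound 2 `CCn1c(CNc2ccccc2)nnc1SCc1nc2cc(C(=O)C(C)C)ccc2o1` is the only member of this set with a plain number: in an assay on isolated protein for inhibition of long-chain fatty acid transport protein 1 (Mus musculus) (on this read-out lower numbers stand for stronger inhibition and higher numbers for weaker inhibition), compound 2 gives 520 nM. Compound 1 `CCn1c(CNc2ccccc2)nnc1SCC(=O)Nc1ccc(Cl)cc1` sits at the limit of > 10000 nM in this assay, at which 1 of the 3 values shown sits. For compound 1 only a limit is reported, > 10000 nM. Compound 3 `CCn1c(CNc2ccccc2)nnc1SCC(=O)Nc1ccc(C(=O)OC)cc1` has no result in this assay, "not determined" (no result reported). Compound 4 `CC/C(=N/O)c1ccc2oc(CSc3nnc(CNc4ccccc4)n3CC)nc2c1` differs from compound 2 by a group of 5 heavy atoms (3 carbon, 1 nitrogen, 1 oxygen; no ring) in place of a group of 5 heavy atoms (4 carbon, 1 oxygen; no ring), on an aromatic carbon, so the isopropylcarbonyl gives way to the entering group while the rest stays the same. Within the data shown here, no pair of measured compounds shows what such a change does, so the expected step from compound 2 to compound 4 is a 1.3-fold higher number from compound 2 to compound 4 (0.13 log units; within the scatter), small and perhaps none beyond the scatter. Compound 4 is estimated at 700 nM, with a range from 200 nM to 2500 nM.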

Compound 4, half-maximal inhibitory concentration: 200 nM
For compound 4 the middle estimate is 3.5-fold (0.54 log units) above the measured one, within the range that was stated.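

Within the data shown here, this is the first measured step at this place on the aromatic carbon: swapping the isopropylcarbonyl for the oxime-type group gives a 2.6-fold lower number from compound 2 to compound 4 (0.41 log units; beyond the scatter). The position therefore accepts a group of equal heavy-atom size that carries a hydrogen-bond donor, and the number moves modestly but beyond the scatter. Nothing shown here explains why the number moves.

One step cannot separate the donor from the changed chain. As far as these compounds go, an ethyl ketone, a methyl ether of the oxime, an amine or a carboxylic acid at this place remains open.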